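This account rests on a few compounds, and the source may have more. Where it says the series, first, only, none or still open, it means among the compounds named here.

For the measured compounds named here, in a functional assay on aorta (Rattus norvegicus) (on this read-out lower numbers stand for stronger inhibition and higher numbers for weaker inhibition), compound 3, with the structure `Cn1nc(CCO[Si](c2ccccc2)(c2ccccc2)C(C)(C)C)ccc1=O`, gives 47000 nM, the only definite number among the three results in hand. Compound 1, with the structure `CC(C)(C)[Si](OCCc1ccc(=O)n(Cc2ccccc2)n1)(c1ccccc1)c1ccccc1`, reaches only the limit > 100000 nM in this assay. Compound 2, with the structure `O=c1ccc(CCCO)nn1Cc1ccccc1`, likewise reaches only the limit > 100000 nM in this assay. Going by the values given here, the one step that can be sized, an at least 2.1-fold lower number from compound 1 to compound 3 (0.32 log units; beyond the scatter), is at least modest and rests on the limit (the limit of > 100000 nM in this assay, at which 2 of the 3 values shown sit), so its true size is open upward.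

Compound 4, with the structure `CC(C)(C)[Si](OCc1ccc(=O)[nH]n1)(c1ccccc1)c1ccccc1`, is not yet measured. It differs from compound 3 by a group of 7 heavy atoms (4 carbon, 2 nitrogen, 1 oxygen; one six-membered aromatic ring with 2 hetero atoms) in place of a group of 9 heavy atoms (6 carbon, 2 nitrogen, 1 oxygen; one six-membered aromatic ring with 2 hetero atoms), on a saturated chain carbon bound to an oxygen on an unsaturated carbon. Among the compounds with values here, this change touches the group bound to the aromatic nitrogen, as the measured step did, but it also alters the chain that carries the oxygen, and no measured pair isolates either part on its own. The measured step points to weaker inhibition when a bulkier group sits on that nitrogen, yet it sets only a lower bound. The step of a 1.3-fold higher number from compound 3 to compound 4 (0.11 log units; within the scatter) is therefore expected to stay within the scatter or to drift slightly toward weaker inhibition. Compound 4 is estimated at 60000 nM in this assay, with a range from 15000 nM to 200000 nM.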

Compound 4, half-maximal inhibitory concentration: 62600 nM
Compound 4: middle estimate off by 1.0-fold (0.02 log units), on the low side; low and high end bracket the measured number.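

In this assay, putting the group of 7 heavy atoms in place of the group of 9 heavy atoms, on a saturated chain carbon bound to an oxygen on an unsaturated carbon, gives a 1.3-fold higher number from compound 3 to compound 4 (0.12 log units; within the scatter), so the two results cannot be told apart. For the compounds shown here, this is the first step here with a definite number at both ends, and it shows that the assay tolerates this swap, even though the entering group carries a hydrogen-bond donor and the leaving group carries none. The earlier step could set only a bound on its size, because so many of the results are not definite numbers: the limit of > 100000 nM in this assay, at which 2 of the 4 values shown sit.

This single swap alters both the group on the aromatic nitrogen and the chain that carries the oxygen, so the compounds shown cannot say whether each part alone does nothing or whether the two parts offset each other. From the compounds shown here alone, it also remains open whether an amine or a carboxylic acid on that chain carbon would bring the number down.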